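Swapping the aryl on the piperazine of a dithiocarbamate series

The compounds below may be only part of what the source reports. "The series", "measured", "known", "first", "only" and "open" are said of these compounds alone.

Measured compounds:
compound 1 `COc1ccc(N2CCN(C(=S)SCc3ccc4nc(N)nc(N)c4c3)CC2)cc1`: 1660 nM
compound 2 `Cc1ccccc1N1CCN(C(=S)SCc2ccc3nc(N)nc(N)c3c2)CC1`: "not determined" (no result reported)
compound 3 `Nc1nc(N)c2cc(CSC(=S)N3CCN(c4ccccc4Cl)CC3)ccc2n1`: 4050 nM

In a functional assay on HeLa cells (Homo sapiens) for antiproliferative activity, read by MTT assay, with a stated time of 72 h (a lower number here means a stronger inhibitor, a higher number a weaker inhibitor), compound 3 gives 4050 nM, the higher of the two numbers available; its nearest neighbour is compound 1, which gives 1660 nM. For compound 2 the result in this assay is "not determined" (no result reported). Among the compounds with values here, the step between compound 1 and compound 3, a 2.4-fold higher number from compound 1 to compound 3 (0.39 log units; beyond the scatter), is the only measured change at this position and lies beyond the scatter. Compound 4 `Nc1nc(N)c2cc(CSC(=S)N3CCN(c4ccccn4)CC3)ccc2n1` differs from compound 3 by pyridin-2-yl in place of 2-chlorophenyl on an amine nitrogen in a ring. Within the data shown here, no measured step involves a heteroaryl group here, so the single modest change from compound 1 to compound 3 gives little guidance, and the expected step in this assay is a 1.4-fold lower number from compound 3 to compound 4 (0.13 log units; within the scatter), not clearly beyond the scatter in either direction. Compound 4 is therefore expected to give about 3000 nM, within 1200 nM to 8000 nM.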

Compound 4, half-maximal inhibitory concentration: 5090 nM
The estimate for compound 4 lay 1.7-fold (0.23 log units) below the measured number, and the stated range covers the measured number.
By their numbers in this assay, from the lowest: compound 1; then compounds 3 and 4 (each within the scatter of the next).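

With pyridin-2-yl, a ring nitrogen reaches this position for the first time among the compounds shown, and in this assay the change is a 1.3-fold higher number from compound 3 to compound 4 (0.10 log units; within the scatter), so this swap does not separate the two groups. Set against 4-methoxyphenyl, the same group gives a 3.1-fold higher number from compound 1 to compound 4 (0.49 log units; beyond the scatter), which leaves compound 1 with the lowest number of the three. No evidence is available on what lies behind these numbers. As far as these compounds go, whether that lower number belongs to the methoxy group or to its place on the aryl ring remains open. From the compounds shown here alone, how a plain phenyl or a 4-chlorophenyl would read here is also open.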